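Hexyl chain replacing the aryl terminus of the alkenyl side chain

A few compounds are considered here, and "the series" means these few. Any claim that something is new, unique, unknown or untested is made for them only; others in the source may bear on it.

For the measured compounds named here, compound 2 `COc1cccc(/C=C/C[C@H]2C[C@@H]([C@@H](O)c3ccccc3)CO[C@@H]2c2ccccc2)c1` gives 9620 nM in a functional assay on HL-60 cells (Homo sapiens) for cytotoxicity, read by WST assay, with a stated time of 48 h (on this read-out higher numbers stand for weaker inhibition and lower numbers for stronger inhibition), the highest of the two numbers so far, though it lies within the scatter of compound 1 `O[C@@H](c1ccccc1)[C@H]1CO[C@H](c2ccccc2)[C@@H](C/C=C/C2CCCCC2)C1`, which gives 6260 nM. Compound 3 `CCCCCC/C=C/C[C@H]1C[C@@H]([C@@H](O)c2ccccc2)CO[C@@H]1c1ccccc1` differs from compound 2 as follows: hexyl in place of 3-methoxyphenyl on a double-bonded chain carbon bound to a double-bonded chain carbon. Going by the values given here, the only comparable step, a 1.5-fold higher number from compound 1 to compound 2 (0.19 log units; within the scatter), exchanged one non-polar terminal group for another without a change beyond the scatter. For compound 3 the expected step is therefore a 1.3-fold lower number from compound 2 to compound 3 (0.11 log units; within the scatter), none beyond the scatter. Compound 3 is estimated at 7500 nM, between 3000 nM and 18000 nM.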

Compound 3, half-maximal inhibitory concentration: 4990 nM
Estimate against measurement, compound 3: 1.5-fold (0.18 log units) above; the range from low to high includes it.
By their numbers in this assay, from the lowest: compounds 3, 1 and 2 (each within the scatter of the next).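

In this assay the terminal group now includes hexyl, which has no ring, and the steps to it, a 1.9-fold lower number from compound 2 to compound 3 (0.29 log units; within the scatter) and a 1.3-fold lower number from compound 1 to compound 3 (0.10 log units; within the scatter), both stay within the scatter. On a double-bonded chain carbon bound to a double-bonded chain carbon, neither the ring of 3-methoxyphenyl or cyclohexyl nor the hydrogen-bond acceptor of 3-methoxyphenyl is needed to keep the number within the scatter in these three compounds. Nothing at hand gives a reason for this result. From the compounds shown here alone, an amine or a carboxylic acid at this place remains open, as does a chain longer than hexyl.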